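This account rests on a few compounds, and the source may have more. Where it says the series, first, only, none or still open, it means among the compounds named here.

Among the measured compounds shown here, in a functional assay on SK-BR-3 cells (Homo sapiens) for antiproliferative activity, read by MTT assay, with a stated time of 72 h (on this read-out higher numbers stand for weaker inhibition and lower numbers for stronger inhibition), compound 1 (`C/C=C1/[C@H](O[C@@H]2O[C@H](COC(C)=O)[C@@H](OC(C)=O)[C@H](OC(C)=O)[C@H]2OC(C)=O)OC=C(C(=O)OC)[C@H]1CC(=O)OCCCCCCCCCCCCCCC`) gives 3810 nM, the only true number so far. Compound 2 (`C/C=C1/[C@H](O[C@@H]2O[C@H](COC(C)=O)[C@@H](OC(C)=O)[C@H](OC(C)=O)[C@H]2OC(C)=O)OC=C(C(=O)OC)[C@H]1CC(=O)O`) gives only a limit, > 15000 nM. Compound 3 (`C/C=C1/[C@H](O[C@@H]2O[C@H](COC(C)=O)[C@@H](OC(C)=O)[C@H](OC(C)=O)[C@H]2OC(C)=O)OC=C(C(=O)OC)[C@H]1CC(=O)SCCc1ccccc1`) also gives only a limit, > 15000 nM. Together these make up (the limit of > 15000 nM in this assay, at which 2 of the 3 values shown sit). Compound 4 (`C/C=C1/[C@H](O[C@@H]2O[C@H](COC(C)=O)[C@@H](OC(C)=O)[C@H](OC(C)=O)[C@H]2OC(C)=O)OC=C(C(=O)OC)[C@H]1CC(=O)OCCC`) carries propoxy in place of phenethylsulfanyl on a carbonyl carbon. For the measured compounds named here, the one measured step, a step that the two limits leave unreadable from compound 2 to compound 3, offers no size to carry over. Compound 1, at 3810 nM, shows that an ester on this carbonyl can give a number, so a true number is possible here as well. The expected change is small, toward slightly stronger inhibition, with an estimated at least 1.1-fold lower number from compound 3 to compound 4 (0.06 log units; that floor lies within the scatter). Compound 4 is estimated at 13000 nM, with a range of 6000 nM to 30000 nM.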

Compound 4, half-maximal inhibitory concentration: 6600 nM
Compound 4: middle estimate off by 2.0-fold (0.29 log units), on the high side, within the range that was stated.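

In this assay, propoxy on this carbonyl carbon gives a true number where phenethylsulfanyl and hydroxy gave only limits, with an at least 2.2-fold lower number from compound 3 to compound 4 (0.35 log units; beyond the scatter) and with an at least 2.2-fold lower number from compound 2 to compound 4 (0.35 log units; beyond the scatter). Both steps are floors and not measured sizes, as each starts from a limit: the limit of > 15000 nM in this assay, at which 2 of the 4 values shown sit.

Between the two esters, the loss of dodecyl from the chain changes little, with a 1.7-fold higher number from compound 1 to compound 4 (0.24 log units; within the scatter). The compounds shown leave open whether the sulfur or the ring of phenethylsulfanyl goes with the limit of compound 3. They also leave open how an amide or a phenethoxy group on this carbonyl carbon would read.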